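The compounds below may be only part of what the source reports. "The series", "measured", "known", "first", "only" and "open" are said of these compounds alone.

In a functional assay on the whole organism with Mus musculus as the target, at a dose of 200 mg/kg by the intravenous route (a higher number here means that more compound is needed for the effect, a lower number that less compound is needed), compound 1 (`C[C@H](NCc1ccc(OCc2ccccc2)cc1)C(N)=O`) gives 16.9 mg/kg as its measured dose, compound 2 (`CNC(=O)[C@@H](CO)NCc1ccc(OCc2ccccc2)cc1`) gives 16.3 mg/kg and compound 3 (`CNC(=O)[C@H](NCc1ccc(OCc2ccccc2)cc1)C(C)O`) gives 21 mg/kg on the same scale. Compound 3 stands level with the other two: all three numbers lie within the usual scatter of one another. The next molecule is compound 4 (`CNC(=O)[C@@H](NCc1ccc(OCc2ccccc2)cc1)C(C)O`), and its relation to compound 3 is simple to state: the two compounds have the same atoms and bonds; at least one stereo element is drawn with a configuration in one of them and without one in the other: 1 of 2 stereo elements differ; a stereocentre at a saturated chain carbon is drawn R in compound 3 and S in compound 4 and nothing else is altered. The two are built from the same pieces, and only the spatial arrangement at that one carbon is different.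

Within the data shown here, no measured pair isolates a change of this kind, so the evidence is indirect. The nearest guides are the steps among the known compounds, a 1.0-fold lower number from compound 1 to compound 2 (0.02 log units; within the scatter), a 1.2-fold higher number from compound 1 to compound 3 (0.09 log units; within the scatter) and a 1.3-fold higher number from compound 2 to compound 3 (0.11 log units; within the scatter), and all of them stay within the scatter. On that basis no shift beyond the scatter is expected, in either direction, although the range has to stay wide because the data lack a direct stereochemical comparison. The expected size of the change is a 1.1-fold higher number from compound 3 to compound 4 (0.06 log units; within the scatter) as an estimate. For compound 4 the estimated dose is 24 mg/kg, with an expected range from 10 mg/kg to 60 mg/kg in this measurement.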

Compound 4, dose for half-maximal effect: 34.2 mg/kg
Compound 4: the middle estimate sits 1.4-fold (0.15 log units) below what was measured; low and high end bracket the measured number.
By their numbers in this assay, from the lowest: compounds 2, 1, 3 and 4 (each within the scatter of the next, the first and the last beyond it).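

Inverting this single stereocentre at a saturated chain carbon gives a 1.6-fold higher number from compound 3 to compound 4 (0.21 log units; within the scatter) in this assay, so in this measurement the spatial arrangement at this position does not, by itself, clearly separate the two compounds. The inversion does alter how the pair relates to the other compounds: the steps of a 2.1-fold higher number from compound 2 to compound 4 (0.32 log units; beyond the scatter) and a 2.0-fold higher number from compound 1 to compound 4 (0.31 log units; beyond the scatter) are both modest but pass the scatter, whereas compound 3 stays within the scatter of compounds 1 and 2. One reservation limits how firmly this result can be tied to a particular configuration: the fact that one of compounds 3 and 4 is drawn with a defined configuration and the other without, at the place where they differ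

What the second stereo element of compounds 3 and 4 contributes remains open, as no pair shown changes that element alone. From the compounds shown here alone, it is also open whether the same stereocentre would matter as much in a side chain carrying an amine or a carboxylic acid in place of the hydroxyl group, or in a longer chain.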